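This account rests on a few compounds, and the source may have more. Where it says the series, first, only, none or still open, it means among the compounds named here.

In an assay on cells for displacement of a labelled ligand from corticotropin-releasing factor receptor 1 (Homo sapiens), with a stated time of 120 min (on this read-out higher numbers stand for weaker inhibition and lower numbers for stronger inhibition), compound 2 `CCN(CC)c1nc(C)nc2c1sc(=N)n2-c1c(C)cc(C)cc1C` gives 891 nM, the larger of the two numbers available, although compound 1 `CCN(CC)c1nc(C)nc2c1s/c(=N/N)n2-c1c(C)cc(C)cc1C`, with 447 nM, lies within the usual scatter of that figure, so the two cannot be told apart. Compound 3 `CCCCN(CC)c1nc(C)nc2c1sc(=N)n2-c1c(C)cc(C)cc1C` differs from compound 2 in a single place: ethyl in place of hydrogen on a saturated chain carbon, two bonds along the chain from a nitrogen on an aromatic ring. Going by the values given here, no measured pair shows the effect of this change, so its size is a guess. The expected step in this assay is a 1.4-fold lower number from compound 2 to compound 3 (0.14 log units; within the scatter), not clearly beyond the scatter in either direction. Compound 3 is therefore estimated at 650 nM, within a range from 200 nM to 2000 nM.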

Compound 3, half-maximal inhibitory concentration: 170 nM
Beside the measured number, compound 3's estimate is 3.8-fold (0.58 log units) above it, outside the stated range (below it).
By their numbers in this assay, from the lowest: compound 3; then compounds 1 and 2 (each within the scatter of the next).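

Going by these compounds alone, replacing diethylamino with butyl(ethyl)amino in this assay gives a 5.2-fold lower number from compound 2 to compound 3 (0.72 log units; beyond the scatter) and is the first change here to move the number beyond the scatter. So this saturated chain carbon accepts an added ethyl, and inhibition grows stronger rather than being lost. No supporting data on the compounds explain this gain.

The compounds shown leave open whether the number depends on chain length, which a propyl or a hexyl chain in place of the butyl would test. They also leave open whether a chain ending in an amine or a hydroxyl group is accepted here.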